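Pyridylmethylpyrrolidine urea in place of a hydroxypyrrolidine urea

This account rests on a few compounds, and the source may have more. Where it says the series, first, only, none or still open, it means among the compounds named here.

Compound 1 `O=C(NC1CCN(Cc2ccn(-c3ccc(C(F)(F)F)cc3)c2)CC1)NS(=O)(=O)c1ccc(F)cc1`: 617 nM
Compound 2 `COc1ccc(OC2CN(C(=O)NC3CCN(Cc4ccn(-c5ccc(C(F)(F)F)cc5)c4)CC3)C2)cc1`: 49 nM
Compound 3 `O=C(NC1CCN(Cc2ccn(-c3ccc(C(F)(F)F)cc3)c2)CC1)N1CC[C@H](O)C1`: 125 nM

In an assay on HEK293 cells for displacement of a labelled ligand from melanin-concentrating hormone receptor 1 (Homo sapiens) (a higher number here means a weaker inhibitor, a lower number a stronger inhibitor), compound 3 stands second of the three numbers: compound 2 gives 49 nM, while compound 1 gives 617 nM. Within the data shown here, the one step measured at the carbonyl carbon, a 4.9-fold lower number from compound 1 to compound 3 (0.69 log units; beyond the scatter), is modest. Compound 4 `O=C(NC1CCN(Cc2ccn(-c3ccc(C(F)(F)F)cc3)c2)CC1)N1CCCC1Cc1cccnc1` differs from compound 3 by 2-((pyridin-3-yl)methyl)pyrrolidin-1-yl in place of 3-hydroxypyrrolidin-1-yl on a carbonyl carbon. Among the measured compounds shown here, no measured step covers this exchange; the values of compound 2 and compound 3 show only that a larger substituent on the pyrrolidine can go with a lower number. A small change, of either sign and not clearly beyond the scatter, is therefore expected, as a 1.3-fold lower number from compound 3 to compound 4 (0.10 log units; within the scatter). For compound 4 the estimated value is 100 nM, in the range 30 nM to 400 nM.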

Compound 4, half-maximal inhibitory concentration: 26 nM
The estimate for compound 4 lay 3.8-fold (0.59 log units) above the measured number; the measured number lies below the stated range.
By their numbers in this assay, from the lowest: compounds 4 and 2 (each within the scatter of the next); then compound 3; then compound 1.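

In this assay the exchange on this carbonyl carbon gives a 4.8-fold lower number from compound 3 to compound 4 (0.68 log units; beyond the scatter) and shows that a low number here does not need the hydrogen-bond donor of 3-hydroxypyrrolidin-1-yl, since 2-((pyridin-3-yl)methyl)pyrrolidin-1-yl has none. Replacing ((4-fluorophenyl)sulfonyl)amino gives a 24-fold lower number from compound 1 to compound 4 (1.38 log units; beyond the scatter) as the largest step yet seen at this position. No measurement shown bears on the cause of either step.

As far as these compounds go, whether the pyridine nitrogen matters stays open, and a benzyl group in place of the (pyridin-3-yl)methyl would test it. From the compounds shown here alone, the entering group has no defined stereocentre, so what each mirror form gives also stays open.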